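Removing a Fluoro Group: From Compound 2 to Compound 3

The compounds below may be only part of what the source reports. "The series", "measured", "known", "first", "only" and "open" are said of these compounds alone.

Compound 1 `N/C(=N\NC(=S)N1CCSCC1)c1ccccn1` gives 80% in a functional assay on A-375 cells (Homo sapiens) for cytotoxicity, read by MTT assay, with a stated time of 72 h, tested at 3 uM; a higher number here means more inhibition of growth at the concentration tested, a lower number less inhibition of growth.
Compound 2 `N/C(=N\NC(=S)N1CCOCC1)c1ccc(F)cn1` gives 66.4% in this assay.

Of these two numbers compound 2 stands lowest; the nearest value, that of compound 1, lies higher by an amount beyond the usual scatter. The two compounds differ in more than one place, so their values can only be set side by side, not traced to a single change.

Compound 3 `N/C(=N\NC(=S)N1CCOCC1)c1ccccn1` has not yet been measured in this assay. It differs from compound 2 in one place: hydrogen in place of fluoro on an aromatic carbon. Going by the values given here, no step between measured compounds isolates this change, so the expectation rests on the values shown. Compound 1, which also carries hydrogen at that place, gives 80%, which suggests a modest rise. The step of a number 5.6 percentage points higher from compound 2 to compound 3 (within the scatter) is expected to be upward but small, possibly within the scatter. For compound 3 the estimate is 72%, with a range from 56% to 88%.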

Compound 3, percent growth inhibition at one concentration: 19.3%
Compound 3: the middle estimate sits 52.7 percentage points above what was measured; the measured number lies below the stated range.
By their numbers in this assay, from the lowest: compound 3; then compound 2; then compound 1.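

In this assay, putting hydrogen in place of fluoro on this aromatic carbon, para to a large group, gives a number 47.1 percentage points lower from compound 2 to compound 3 (beyond the scatter), so with morpholin-4-yl on the thiocarbonyl carbon this single atom makes a large difference. Hydrogen at that place does not always go with a low number, though: morpholin-4-yl in place of thiomorpholin-4-yl gives a number 60.7 percentage points lower from compound 1 to compound 3 (beyond the scatter). Compound 1 and compound 2 differ in more than one place and could not show this, whereas compound 3 links each of them to a single change.

As far as these compounds go, whether fluoro would make a similar difference alongside thiomorpholin-4-yl stays open, as does what chloro, a methoxy group or an amine would do on the same aromatic carbon. Nothing shown here explains why either change moves the number so far.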